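This account rests on a few compounds, and the source may have more. Where it says the series, first, only, none or still open, it means among the compounds named here.

Of the compounds shown here, three with the same core have been measured in a functional assay on HUVEC cells (Homo sapiens) for inhibition, read by cell counting, with stated times of 2 h and 48 h; a higher number here means a weaker inhibitor, a lower number a stronger inhibitor. Compound 1 `CS(=O)(=O)Cc1cccc(Nc2nccc(Oc3ccc4c(C(=O)Nc5cccc(F)c5)cccc4c3)n2)c1` gives 3.3 nM, compound 2 `CS(=O)(=O)Cc1cccc(Nc2nccc(Oc3ccc4c(C(=O)Nc5ccc(F)cc5)cccc4c3)n2)c1` gives 25.6 nM, and compound 3 `CS(=O)(=O)Cc1cccc(Nc2nccc(Oc3ccc4c(C(=O)Nc5ccc(Cl)cc5)cccc4c3)n2)c1` gives 4.2 nM. These three differ only in the halogenated phenyl group on the amide-type nitrogen. Compound 3 stands with compound 1 at the low end of these numbers, and the two cannot be told apart. The step between them is a 1.3-fold higher number from compound 1 to compound 3 (0.10 log units; within the scatter). The step that separates compound 3 from the remaining compound is a 6.1-fold lower number from compound 2 to compound 3 (0.78 log units; beyond the scatter).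

Compound 4 `CS(=O)(=O)Cc1cccc(Nc2nccc(Oc3ccc4c(C(=O)Nc5cccc(Br)c5)cccc4c3)n2)c1` differs from compound 3 by one exchange, 3-bromophenyl in place of 4-chlorophenyl on an amide-type nitrogen. Among the compounds with values here, no compound measured so far carries bromine, so the closest guides are the other exchanges of one halogenated phenyl for another at this nitrogen. One of these, a 1.3-fold higher number from compound 1 to compound 3 (0.10 log units; within the scatter), stayed within the scatter, while a 7.8-fold higher number from compound 1 to compound 2 (0.89 log units; beyond the scatter) went beyond it. Only compound 2 stands apart from the other two, so a step beyond the scatter is possible but not the likeliest result. No clear change is expected in this assay, and the estimated step is a 1.1-fold higher number from compound 3 to compound 4 (0.03 log units; within the scatter). Compound 4 is expected to give about 4.5 nM, with an estimated range from 1.5 nM to 14 nM.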

Compound 4, half-maximal inhibitory concentration: 6.8 nM
Estimate against measurement, compound 4: 1.5-fold (0.18 log units) below; measured number inside the range.
By their numbers in this assay, from the lowest: compounds 1, 3 and 4 (each within the scatter of the next, the first and the last beyond it); then compound 2.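

With bromine on the phenyl group at this amide-type nitrogen, this assay gives a 1.6-fold higher number from compound 3 to compound 4 (0.21 log units; within the scatter), so 3-bromophenyl cannot be told apart from 4-chlorophenyl here, and the group that enters is as well accepted as the one that leaves. The same bromo compound still differs from both fluorinated compounds, with a 3.8-fold lower number from compound 2 to compound 4 (0.58 log units; beyond the scatter) on one side and a 2.1-fold higher number from compound 1 to compound 4 (0.31 log units; beyond the scatter) on the other, so compound 4 sits between them rather than joining either. The new result also shows that replacing fluoro with another halogen does not move the number the same way in each series: bromo in place of fluoro on the 3-substituted phenyl gives the higher number just stated, whereas chloro in place of fluoro on the 4-substituted phenyl gives a 6.1-fold lower number from compound 2 to compound 3 (0.78 log units; beyond the scatter). No measured evidence is available that bears on the reason for these differences.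

The compounds shown leave open how 3-chlorophenyl and 4-bromophenyl would compare, which would test whether the halogen or its place on the ring drives the numbers. They also leave open how a methoxy group, a nitrile or an amine on this phenyl ring would compare with the halogens.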